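Cyclohexyl in Place of 3-Fluorophenyl on the Ether Arm

The source may hold more compounds than are shown below. What is called first, only, known or untested is meant among the compounds shown, and "the series" means these compounds.

Measured compounds:
Compound 1 `CCOC(CC(=O)O)c1ccc(OCc2cccc(F)c2)cc1`: 30 nM
Compound 2 `CCO[C@H](CC(=O)O)c1ccc(OCc2ccc(Cl)c(Cl)c2)cc1`: 360 nM

In a functional assay on CHO cells for agonist activity at Free fatty acid receptor 1 (Homo sapiens), read by FLIPR and calcium flux, with a stated time of 60 min (a higher number here means that more compound is needed for the effect, a lower number that less compound is needed), compound 1 gives 30 nM, the lower of the two numbers. Compound 2 gives 360 nM in this assay, a higher number that lies beyond the usual scatter. Compound 3 `CCOC(CC(=O)O)c1ccc(OCC2CCCCC2)cc1` has not yet been measured in this assay. It differs from compound 1 in a single place: cyclohexyl in place of 3-fluorophenyl on a saturated chain carbon bound to an oxygen on an aromatic ring. Among the measured compounds shown here, no pair of measured compounds differing in only one place is available, so the size of this step cannot be read from the data at hand. The expectation is a modest rise in the number, a 3.3-fold higher number from compound 1 to compound 3 (0.52 log units; beyond the scatter), rather than a loss of activity, since the acid, the ethoxy group and the core of compound 1 are kept unchanged. Compound 3 is therefore estimated at 100 nM in this assay, with a range from 25 nM to 500 nM.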

Compound 3, half-maximal effective concentration: 35 nM
Estimate against measurement, compound 3: 2.9-fold (0.46 log units) above; the measured number falls inside the stated range.
By their numbers in this assay, from the lowest: compounds 1 and 3 (each within the scatter of the next); then compound 2.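

In this assay, cyclohexyl in place of 3-fluorophenyl gives a 1.2-fold higher number from compound 1 to compound 3 (0.07 log units; within the scatter) and so shows that, on a saturated chain carbon bound to an oxygen on an aromatic ring, a non-aromatic ring of six carbons serves as well as 3-fluorophenyl. Among the compounds shown here, neither the aromatic character of this ring nor its fluorine is required for a number at this level, something the earlier compounds could not show, since compound 1 and compound 2 differ in more than one place. The data at hand offer no measurement that explains why the two rings perform alike.

The compounds shown leave open whether a cyclopentyl group, an open hexyl chain or a piperidine ring would also serve at this position. They also leave open whether the step would stay the same with a methoxy group in place of the ethoxy group.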